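The compounds below may be only part of what the source reports. "The series", "measured", "known", "first", "only" and "open" are said of these compounds alone.

Compound 1 `O=C(Cn1ccnc1)N1CCC(NS(=O)(=O)c2cc(S(=O)(=O)c3ccccc3)ccc2C(F)(F)F)CC1`: 100000 nM
Compound 2 `CC(C)(C)C(=O)N1CCC[C@H]1C(=O)N1CCC(NS(=O)(=O)c2cc(S(=O)(=O)c3ccccc3)ccc2C(F)(F)F)CC1`: 50000 nM
Compound 3 `CN(C)c1ccc(C(=O)N2CCC[C@H]2C(=O)N2CCC(NS(=O)(=O)c3cc(S(=O)(=O)c4ccccc4)ccc3C(F)(F)F)CC2)cc1`: 100000 nM

In a physicochemical assay for solubility (a higher number here means a more soluble compound, a lower number a less soluble compound), compound 3 stands level with compound 1, and compound 2 lies within the scatter of both. Compound 4 `CN(C)C(=O)N1CCC[C@H]1C(=O)N1CCC(NS(=O)(=O)c2cc(S(=O)(=O)c3ccccc3)ccc2C(F)(F)F)CC1` keeps the shared core and changes one group: dimethylamino in place of 4-(dimethylamino)phenyl on a carbonyl carbon. Here dimethylamino takes the place of 4-(dimethylamino)phenyl on a carbonyl carbon. Among the measured compounds shown here, two measured steps bear on this change, each swapping a group on a carbonyl carbon: a 2.0-fold lower number from compound 1 to compound 2 (0.30 log units; within the scatter), and a 2.0-fold higher number from compound 2 to compound 3 (0.30 log units; within the scatter). The second changes the same group as the new step does. Neither step goes beyond the scatter, so none beyond the scatter is expected here either, and the expected change is a 1.3-fold lower number from compound 3 to compound 4 (0.10 log units; within the scatter). Compound 4 is estimated at 80000 nM, with an expected range of 35000 nM to 150000 nM.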

Compound 4, solubility: 100000 nM
Compound 4: middle estimate off by 1.3-fold (0.10 log units), on the low side; low and high end bracket the measured number.
By their numbers in this assay, from the lowest: compounds 2, 1, 3 and 4 (each within the scatter of the next).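

In this assay, a much smaller group without a ring can stand on this carbonyl carbon: dimethylamino in place of 4-(dimethylamino)phenyl gives no change at the digits printed from compound 3 to compound 4 (within the scatter). Dimethylamino in place of tert-butyl gives a 2.0-fold higher number from compound 2 to compound 4 (0.30 log units; within the scatter), and 1-(dimethylcarbamoyl)pyrrolidin-2-yl in place of (1H-imidazol-1-yl)methyl gives no change at the digits printed from compound 1 to compound 4 (within the scatter), so none of these swaps goes beyond the scatter. Nothing available explains this result. On these data alone, it remains open whether a carboxylic acid or a primary amine on this carbonyl carbon would give a step beyond the scatter.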